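This account rests on a few compounds, and the source may have more. Where it says the series, first, only, none or still open, it means among the compounds named here.

Measured compounds:
Compound 1, `COC(=O)[C@@H]1CSCc2ccccc2C(=O)OC[C@H](NC(=O)[C@@H]2CCCN2C(C)=O)CN1`, giving 0.7
Compound 2, `COC(=O)[C@H]1CSCc2ccccc2C(=O)OC[C@@H](NC(=O)[C@@H]2CCCN2C(C)=O)CN1`, giving 0.6

Among the measured compounds shown here, in a physicochemical assay for lipophilicity, read by HPLC, at pH 7.4 (a lower number here means a more polar compound, a higher number a more lipophilic compound), compound 2 stands at the lower of the two numbers; its only neighbour is compound 1, and the step of a number 0.10 log units lower from compound 1 to compound 2 (within the scatter) is within the usual scatter, so the two compounds cannot be placed in order against each other. The two share all atoms and bonds, and the fact that they differ only in configuration as drawn the fact that compounds 1 and 2 differ only in the configuration as drawn is all that separates them.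

Compound 3 is `COC(=O)[C@@H]1CSCc2ccccc2C(=O)OC[C@@H](NC(=O)[C@@H]2CCCN2C(C)=O)CN1`. Its relation to compound 2 is this: the two compounds have the same atoms and bonds and differ only in configuration as drawn: 1 of 3 stereo elements differ; a stereocentre at a saturated ring carbon is drawn S in compound 2 and R in compound 3. Compound 3 thus carries the configuration of compound 1 at one ring carbon and that of compound 2 at the other two stereo elements.

For the measured compounds named here, the one measured step that bears on such a change is a number 0.10 log units lower from compound 1 to compound 2 (within the scatter), where two stereocentres were inverted together and the number stayed within the scatter. Going by the values given here, for the single inversion from compound 2 to compound 3 no step beyond the scatter is therefore expected in this assay, the expected step being a number 0.05 log units higher from compound 2 to compound 3 (within the scatter). Compound 3 is accordingly estimated at 0.65, within a range from 0.3 to 1.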

Compound 3, distribution coefficient: 0.43
Compound 3: middle estimate off by 0.22 log units, on the high side; measured number inside the range.
By their numbers in this assay, from the lowest: compounds 3, 2 and 1 (each within the scatter of the next).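

In this assay, compound 3 lets a single inverted stereocentre at a saturated ring carbon be read on its own, which the earlier pair, with two inverted together, did not allow: the change at one ring carbon gives a number 0.17 log units lower from compound 2 to compound 3 (within the scatter), and the change at the other gives a number 0.27 log units lower from compound 1 to compound 3 (within the scatter). Both steps stay within the usual scatter, so neither ring carbon can be told apart from the other by its effect on this number, and compounds 1, 2 and 3 cannot be placed in order against one another. Across these three compounds, then, configuration at either ring carbon brings no step beyond the scatter, and the comparison is a clean one, with no change of atoms or bonds to confound it: the fact that compounds 1 and 3 differ only in the configuration as drawn

Going by these compounds, the third stereo element is drawn the same in all three compounds, so what its inversion would do in this assay stays open. Equally open, on these data alone, is whether a carboxylic acid, an amine or a longer chain on the shared core would bring a step beyond the scatter, and whether the configuration would then still count for as little.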